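The source may report more compounds than this note shows. Statements on the series, on what has been measured and on what is new or still open speak of the compounds shown alone.

Compound 1 `Cc1ccc2nc(C(=O)Nc3c(F)cc(-c4cccc(F)c4)cc3F)c(C)c(O)c2c1` gives 0.98% in a functional assay on Hep 3B2 cells (Homo sapiens) for antiproliferative activity, read by MTT assay, with a stated time of 24 h, tested at 0.02 ug/mL; a lower number here means a weaker effect, a higher number a stronger effect of the compound at the concentration tested.
Compound 2 `CCc1ccc2nc(C(=O)Nc3c(F)cc(-c4cccc(F)c4)cc3F)c(C)c(O)c2c1` gives 2.05% in this assay.

Both numbers are small, and the step of a number 1.1 percentage points higher from compound 1 to compound 2 (within the scatter) lies within the scatter, so compound 2 and compound 1 sit together at a weak effect. Compound 3 `Cc1c(C(=O)Nc2c(F)cc(-c3cccc(F)c3)cc2F)nc2ccc(F)cc2c1O` differs from compound 2 in one place: fluoro in place of ethyl on an aromatic carbon. Within the data shown here, the only measured step, methyl in place of hydrogen on a saturated chain carbon, is a different kind of change at a different place, and it moved this assay by an amount within the scatter. Among the measured compounds shown here, no measured step bears directly on a fluoro for an ethyl, so the expectation for this assay rests on the weak effect shared by both measured compounds, and no step beyond the scatter is expected. Compound 3 is therefore estimated to give 2%, between 0% and 9%. The expected step is a number 0.1 percentage points lower from compound 2 to compound 3 (within the scatter).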

Compound 3, a percentage reported as inhibition, at one concentration (the size of the read-out at that concentration, not a potency): 0.35%
Compound 3: the middle estimate sits 1.7 percentage points above what was measured; the range from low to high includes it.
By their numbers in this assay, from the lowest: compounds 3, 1 and 2 (each within the scatter of the next).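

In this assay, placing a fluoro on this aromatic carbon of the shared core gives a result that cannot be told apart from either alkyl group: fluoro in place of ethyl gives (a number 1.7 percentage points lower from compound 2 to compound 3 (within the scatter)) and fluoro in place of methyl gives (a number 0.6 percentage points lower from compound 1 to compound 3 (within the scatter)). This position has now carried a single halogen atom as well as two carbon chains of different length, and all three compounds sit together at a weak effect at the one concentration tested. No measurement here explains why these changes leave the read-out where it is.

Going by these compounds, whether any group at this position can lift the effect well clear of these low values remains open. An amine, a carboxylic acid or a longer chain on this carbon would test that.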